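Chloro for methyl on the fused ring: compound 3

A few compounds are considered here, and "the series" means these few. Any claim that something is new, unique, unknown or untested is made for them only; others in the source may bear on it.

Measured so far in an assay for inhibition of Polyunsaturated fatty acid 5-lipoxygenase (Homo sapiens), read by HPLC, with a stated time of 15 min; a lower number here means a stronger inhibitor, a higher number a weaker inhibitor:
compound 1 `COc1cc(-c2nc3ccc(Cl)cn3c2NC2CCCCC2)ccc1OCCCNC(=O)Nc1ccc(C(F)(F)F)cc1` gives 336 nM
compound 2 `COc1cc(-c2nc3ccc(C)cn3c2NC(C)C)ccc1OCCCNC(=O)Nc1ccc(C(F)(F)F)cc1` gives 620 nM

Compound 2 stands within the scatter of compound 1; the two differ in two places at once, so these two values show no separate effect of either change.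

Compound 3 `COc1cc(-c2nc3ccc(Cl)cn3c2NC(C)C)ccc1OCCCNC(=O)Nc1ccc(C(F)(F)F)cc1` is not yet measured. It differs from compound 2 in one place: chloro in place of methyl on an aromatic carbon. Compound 3 thus carries the chloro of compound 1 together with the amine of compound 2. Among the measured compounds shown here, no single-change step at this position is known. The expected step from compound 2 to compound 3 is no larger than the scatter, with a slight lean toward a lower number, estimated as a 1.4-fold lower number from compound 2 to compound 3 (0.14 log units; within the scatter). Compound 3 is expected near 450 nM, within a range of 200 nM to 1000 nM.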

Compound 3, half-maximal inhibitory concentration: 439 nM
For compound 3 the middle estimate is 1.0-fold (0.01 log units) above the measured one, within the range that was stated.
By their numbers in this assay, from the lowest: compounds 1, 3 and 2 (each within the scatter of the next).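

Compound 3 resolves the double difference between compound 1 and compound 2 into two single changes, each readable in this assay. Chloro in place of methyl on an aromatic carbon gives a 1.4-fold lower number from compound 2 to compound 3 (0.15 log units; within the scatter) and isopropyl in place of cyclohexyl on the nitrogen gives a 1.3-fold higher number from compound 1 to compound 3 (0.12 log units; within the scatter) so neither change, taken alone, separates from the scatter in this series. No measurement bearing on the cause of either step is available.

Still open, as far as these compounds go, is whether another group on this aromatic carbon, such as hydrogen, methoxy or nitrile, would give a step beyond the scatter. The same question stands for the nitrogen substituent, where a cyclopropyl group or a longer chain could be compared with isopropyl and cyclohexyl.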